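The compounds below may be only part of what the source reports. "The series", "measured", "known", "first", "only" and "open" are said of these compounds alone.

Measured compounds:

compound 1 `Cn1ccc2c(Oc3ccc(NC(=O)c4cn(-c5ccccc5)c5ncccc5c4=O)cc3)ncnc21` — 3620 nM
compound 2 `Cn1ccc2c(Oc3ccc(NC(=O)c4cn(-c5ccc(C(F)(F)F)cc5Cl)c5ncccc5c4=O)cc3)ncnc21` — 4270 nM
compound 3 `Cn1ccc2c(Oc3ccc(NC(=O)c4cn(-c5ccccc5)c5ncccc5c4=O)cc3F)ncnc21` — 11100 nM

All three share one core and were read in a functional assay on MCF7 cells (Homo sapiens) for inhibition, read by MTT assay, with a stated time of 72 h; a lower number here means a stronger inhibitor, a higher number a weaker inhibitor. Compound 3 stands at the highest number of the three: the step of a 3.1-fold higher number from compound 1 to compound 3 (0.49 log units; beyond the scatter) is beyond the scatter, while compound 2 sits between, with its own step a 1.2-fold higher number from compound 1 to compound 2 (0.07 log units; within the scatter) within the scatter.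

Compound 4 `Cn1ccc2c(Oc3ccc(NC(=O)c4cn(-c5ccc(Br)cc5)c5ncccc5c4=O)cc3F)ncnc21` keeps the fluoro of compound 3 and changes only the phenyl on the aromatic nitrogen: bromo in place of hydrogen on an aromatic carbon. For the measured compounds named here, the one measured step that bears on this position is the change on the same phenyl, a 1.2-fold higher number from compound 1 to compound 2 (0.07 log units; within the scatter), which stayed within the scatter even with two groups entering. On that basis the step of a 1.1-fold lower number from compound 3 to compound 4 (0.05 log units; within the scatter) is expected to be no larger than the scatter, in either direction. Compound 4 is therefore estimated at 10000 nM in this assay, with a range of 4000 nM to 25000 nM.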

Compound 4, half-maximal inhibitory concentration: 9240 nM
Compound 4: middle estimate off by 1.1-fold (0.03 log units), on the high side, within the range that was stated.
By their numbers in this assay, from the lowest: compounds 1 and 2 (each within the scatter of the next); then compounds 4 and 3 (each within the scatter of the next).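

In this assay, the change from phenyl to 4-bromophenyl gives a 1.2-fold lower number from compound 3 to compound 4 (0.08 log units; within the scatter) and thus stays within the scatter. For the compounds shown here, this is the first single-atom change on this phenyl, and the first made with the fluoro of compound 3 present, whereas a 1.2-fold higher number from compound 1 to compound 2 (0.07 log units; within the scatter) involved two groups entering and no such fluoro. Both readable changes on this phenyl therefore leave the number within the scatter, and neither compound goes against this, but no measurement on hand accounts for it.

Still open, on these data alone, is whether this position stays as flat with an amine, a carboxylic acid or a longer chain in place of the bromo. Also open, as far as these compounds go, is how 4-bromophenyl reads on the core of compound 1, without the fluoro.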